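The source may hold more compounds than are shown below. What is called first, only, known or untested is meant among the compounds shown, and "the series" means these compounds.

Measured in a functional assay on A549 cells (Homo sapiens) for inhibition, read by MTT assay, with a stated time of 48 h; on this read-out lower numbers stand for stronger inhibition and higher numbers for weaker inhibition:
- compound 1 `Oc1cccc(C(c2c[nH]c3ccc(Br)cc23)c2c[nH]c3ccc(Br)cc23)c1` gives 8000 nM
- compound 2 `COc1ccc(C(c2c[nH]c3ccc(Br)cc23)c2c[nH]c3ccc(Br)cc23)c(OC)c1` gives 100000 nM
- compound 3 `CN(C)c1ccc(C(c2c[nH]c3ccc(Br)cc23)c2c[nH]c3ccc(Br)cc23)cc1` gives 25000 nM

Compound 3 holds the middle place among the three numbers. Its position is set by a 3.1-fold higher number from compound 1 to compound 3 (0.49 log units; beyond the scatter) and by a 4.0-fold lower number from compound 2 to compound 3 (0.60 log units; beyond the scatter).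

The next compound is compound 4 `Brc1ccc2[nH]cc(C(c3ccc4ccccc4c3)c3c[nH]c4ccc(Br)cc34)c2c1`, which keeps the shared core and changes one group: naphthalen-2-yl in place of 4-(dimethylamino)phenyl on a saturated chain carbon bound to two aromatic carbons. Going by the values given here, no measured compound carries naphthalen-2-yl, so no measured step addresses this group directly. The nearest evidence comes from the other swaps at the same place, on a saturated chain carbon bound to two aromatic carbons. Besides the two steps above, these include a 13-fold higher number from compound 1 to compound 2 (1.10 log units; beyond the scatter). The read-out in this assay therefore moves by modest to large steps when this group changes, but three compounds give no rule for predicting the direction of a new swap. The expectation stays close to compound 3 at 25000 nM, with no direction favoured and no step beyond the scatter as the likeliest outcome. The expected change is a 1.3-fold lower number from compound 3 to compound 4 (0.10 log units; within the scatter). The estimated value for compound 4 is 20000 nM, with an expected range from 7000 nM to 60000 nM.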

Compound 4, half-maximal inhibitory concentration: 8500 nM
For compound 4 the middle estimate is 2.4-fold (0.37 log units) above the measured one, within the range that was stated.
By their numbers in this assay, from the lowest: compounds 1 and 4 (each within the scatter of the next); then compound 3; then compound 2.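

In this assay, a hydroxyl group is not needed on the group at the saturated chain carbon bound to two aromatic carbons for a number at the low end of this series: naphthalen-2-yl, with no hydrogen-bond donor or acceptor, in place of 3-hydroxyphenyl gives a 1.1-fold higher number from compound 1 to compound 4 (0.03 log units; within the scatter). The same group set against the two other aryl groups gives a 2.9-fold lower number from compound 3 to compound 4 (0.47 log units; beyond the scatter) and a 12-fold lower number from compound 2 to compound 4 (1.07 log units; beyond the scatter), so a second six-membered aromatic ring of carbon only is tolerated at this place, and the two substituted phenyl groups without a hydroxyl are the ones with the higher numbers. No measurement at hand accounts for these steps.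

The four compounds do not show whether the low numbers of the hydroxylated and the naphthalene compounds have anything in common, and with so few groups, no rule for this position can be drawn. From the compounds shown here alone, how plain phenyl, a carboxylic acid or an amine on a longer chain would read at this carbon stays open, as does any change to the bromine atoms on the shared core.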